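This account rests on a few compounds, and the source may have more. Where it says the series, first, only, none or still open, it means among the compounds named here.

Measured so far in a functional assay on A549 cells (Homo sapiens) for antiproliferative activity, read by MTT assay, with a stated time of 72 h; a higher number here means a weaker inhibitor, a lower number a stronger inhibitor
Compound 1 `C=CC(=O)Nc1cc2c(Nc3ccc(OCc4cccc(F)c4)c(Cl)c3)ncnc2cc1OCc1cn(CCCC(=O)NO)nn1` gives > 50000 nM
Compound 2 `C=CC(=O)Nc1cc2c(Nc3ccc(F)c(Cl)c3)ncnc2cc1OCc1cn(CCC(=O)NO)nn1` gives > 50000 nM
Compound 3 `CN(C)C/C=C/C(=O)Nc1cc2ncnc(Nc3ccc(F)c(Cl)c3)c2cc1O[C@@H]1CCOC1` gives 1900 nM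

Compound 2 stands at a limit of the assay (> 50000 nM), which is not a true number. Compound 1 likewise gives only a limit (> 50000 nM). Only compound 3 gives a number (1900 nM).

Compound 4 `C=CC(=O)Nc1cc2c(Nc3ccc(F)c(Cl)c3)ncnc2cc1OCc1cn(CCCCC(=O)NO)nn1` differs from compound 2 in its side chain (2-(hydroxycarbamoyl)ethyl in place of hydroxycarbamoyl on a saturated chain carbon, two bonds along the chain from an aromatic nitrogen), with 4-(hydroxycarbamoyl)butyl in place of 2-(hydroxycarbamoyl)ethyl. Among the compounds with values here, no measured pair shows what this change does. A small gain in strength or none beyond the scatter is expected, and the estimated change (an at least 2.0-fold lower number from compound 2 to compound 4 (0.30 log units; that floor lies within the scatter)) is modest, with the reading quite possibly remaining at the limit. For compound 4 the estimated value is 25000 nM, with an expected range from 5000 nM to 50000 nM.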

Compound 4, half-maximal inhibitory concentration: > 50000 nM
Compound 4: only a limit was reported; the forecaster's own chance of this, stated with the estimate: 50%; middle value at least 2.0-fold (0.30 log units) from the limit.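

Compound 2 and compound 4 both give only a limit, so no step between them can be read: the limit of > 50000 nM in this assay, at which 3 of the 4 values shown sit.

As far as these compounds go, whether 4-(hydroxycarbamoyl)butyl in place of 2-(hydroxycarbamoyl)ethyl changes the strength at all stays open.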